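Cyclohexyl on the ring nitrogen of compound 1

The source may report more compounds than this note shows. Statements on the series, on what has been measured and on what is new or still open speak of the compounds shown alone.

Within the data shown here, compound 1 `Cc1nn(C)c2c1C(c1ccccc1Cl)=NCC(=O)N2` carries the only number in this set: in a functional assay on the whole organism (strain Holtzman) with Rattus norvegicus as the target (on this read-out lower numbers stand for an effect already at smaller amounts and higher numbers for an effect only at larger amounts of compound), compound 1 gives 2.5 mg/kg. Compound 2 `CC(C)c1nn(C)c2c1C(c1ccccc1Cl)=NCC(=O)N2` reaches only a limit, > 40 mg/kg. Compound 3 `CCCCc1nn(C)c2c1C(c1ccccc1Cl)=NCC(=O)N2` likewise stops at a limit, > 40 mg/kg. Both limits sit at the limit of > 40 mg/kg in this assay, at which 2 of the 3 values shown sit. The two readable steps, an at least 16-fold higher number from compound 1 to compound 2 (1.20 log units; beyond the scatter) and an at least 16-fold higher number from compound 1 to compound 3 (1.20 log units; beyond the scatter), each enlarge the group on the aromatic carbon; the step that the two limits leave unreadable from compound 2 to compound 3 stays unreadable. Compound 4 `Cc1nn(C2CCCCC2)c2c1C(c1ccccc1Cl)=NCC(=O)N2` alters another place: cyclohexyl in place of methyl on an aromatic nitrogen. Among the measured compounds shown here, no measured step touches that nitrogen, so the enlargements on the aromatic carbon, both large losses, are the only guide. A loss is therefore expected for compound 4 too, tempered by the different place, as the expected step of a 6.0-fold higher number from compound 1 to compound 4 (0.78 log units; beyond the scatter). Compound 4 is estimated at 15 mg/kg, within 4 mg/kg to 60 mg/kg.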

Compound 4, minimum effective dose: > 40 mg/kg
Compound 4: only a limit was reported (the forecaster's own chance of this, stated with the estimate: 40%); middle value at least 2.6-fold (0.42 log units) from the limit.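

The aromatic nitrogen now has a measured step of its own in this assay: an at least 16-fold higher number from compound 1 to compound 4 (1.20 log units; beyond the scatter). The loss seen with larger groups on the aromatic carbon therefore also appears with cyclohexyl at this second place on the shared core. Compound 4 reaches only a limit, > 40 mg/kg, so the full size of its step cannot be read, and it joins the other limits: the limit of > 40 mg/kg in this assay, at which 3 of the 4 values shown sit.

Open, as far as these compounds go, is whether ethyl or hydrogen on this nitrogen stays close to compound 1 at 2.5 mg/kg. Also open, from the compounds shown here alone, is whether a chain carrying an amine behaves differently from cyclohexyl here.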